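Swapping naphthalen-2-yl for 1-benzothiophen-2-yl on a sulfonyl sulfur

A few compounds are considered here, and "the series" means these few. Any claim that something is new, unique, unknown or untested is made for them only; others in the source may bear on it.

Of the compounds shown here, two built on the same core have been tested so far. In an ADME assay on Chem1 cells (Homo sapiens) for cytotoxicity (on this read-out higher numbers stand for lower toxicity in this test and lower numbers for higher toxicity in this test), compound 1 (`NCCCCN(C[C@H]1CN(C(=O)OCc2ccccc2)CCN1)[C@H]1CCCc2cccnc21`) gives > 10 uM, which is a limit of the test and not a number. In this assay compound 2 (`NCCCCN(C[C@H]1CN(S(=O)(=O)c2ccc3ccccc3c2)CCN1)[C@H]1CCCc2cccnc21`) gives > 10 uM, which is again a limit and not a number. Compound 2 therefore has no exact position, and the picture so far is the limit of > 10 uM in this assay, at which 2 of the 2 values shown sit.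

Compound 3 (`NCCCCN(C[C@H]1CN(S(=O)(=O)c2cc3ccccc3s2)CCN1)[C@H]1CCCc2cccnc21`) alters one group of compound 2: 1-benzothiophen-2-yl in place of naphthalen-2-yl on a sulfonyl sulfur. Put simply, 1-benzothiophen-2-yl stands in place of naphthalen-2-yl on a sulfonyl sulfur. Among the compounds with values here, no measured pair shows what such a swap does in this assay, so no step beyond the usual scatter is expected, in either direction. This expectation leans on compound 2, whose > 10 uM is a limit. The expected change is a step that the limit leaves unreadable from compound 2 to compound 3. Compound 3 is estimated at 20 uM, with an expected range from 8 uM to 50 uM.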

Compound 3, half-maximal toxic concentration: > 10 uM
Compound 3 ended at the assay's limit (the forecaster's own chance of this, stated with the estimate: 75%); the middle value does not contradict the limit.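

No step can be read from compound 2 to compound 3, because both results are limits of the test and not numbers: the limit of > 10 uM in this assay, at which 3 of the 3 values shown sit.

The compounds shown leave open where the true values lie in this assay, and whether 1-benzothiophen-2-yl in place of naphthalen-2-yl changes the result at all.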